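The source may report more compounds than this note shows. Statements on the series, on what has been measured and on what is new or still open speak of the compounds shown alone.

Compound 1 `C[C@H](NC(=O)[C@]1(Cc2ccccc2)CCN1C(=O)OCc1ccccc1)C(=O)N(C)C` was tested in an ADME assay on HELF cells (Homo sapiens) for cytotoxicity, with a stated time of 3 days; on this read-out lower numbers stand for higher toxicity in this test and higher numbers for lower toxicity in this test. In this assay compound 1 gives > 100000 nM, which is a limit of the assay rather than a measured number. Compound 2 `C[C@H](NC(=O)[C@]1(Cc2ccccc2)CCN1S(=O)(=O)c1ccc2ccccc2c1)C(N)=O` shares the core of compound 1 but differs elsewhere in its structure. In this assay compound 2 gives > 100000 nM, again a limit and not a number. Going by the values given here, both results sit at the limit of > 100000 nM in this assay, at which 2 of the 2 values shown sit, so compound 1 stands at the limit beside the only other measured compound, and no step between two measured compounds can be computed. Compound 3 `CC(C)CNC(=O)[C@H](C)NC(=O)[C@]1(Cc2ccccc2)CCN1C(=O)OCc1ccccc1` differs from compound 1 in one place: isobutylamino in place of dimethylamino on a carbonyl carbon Because both measured compounds sit at the limit of > 100000 nM in this assay, at which 2 of the 2 values shown sit, the step from compound 1 to compound 3 is expected to stay within the scatter, a step that the limit leaves unreadable from compound 1 to compound 3. Compound 3 is therefore expected to give 150000 nM, within a range from 60000 nM to 400000 nM, most likely reported only as a limit once more.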

Compound 3, half-maximal cytotoxic concentration: > 100000 nM
Compound 3 gave a limit, no number (the forecaster's own chance of this, stated with the estimate: 85%); the middle value does not contradict the limit.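

No step can be read from compound 1 to compound 3, as both results are limits and not numbers: the limit of > 100000 nM in this assay, at which 3 of the 3 values shown sit. The compounds shown leave open whether isobutylamino in place of dimethylamino on a carbonyl carbon changes the result in this assay at all.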